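The source may hold more compounds than are shown below. What is called first, only, known or untested is meant among the compounds shown, and "the series" means these compounds.

Three esters and ethers of one shared core have been tested in a functional assay on HeLa cells (Homo sapiens) for cytotoxicity, read by MTT assay; a lower number here means a stronger inhibitor, a higher number a weaker inhibitor. There, compound 1 (`CCCC(O)CC(=O)O[C@H](CC=C(C)C)C1=CC(=O)c2c(O)ccc(O)c2C1=O`) gives 59300 nM and compound 2 (`COCCO[C@H](CC=C(C)C)C1=CC(=O)c2c(O)ccc(O)c2C1=O`) gives 62400 nM, and the step between them, a 1.1-fold higher number from compound 1 to compound 2 (0.02 log units; within the scatter), lies within the scatter. Compound 3 (`CCCCCCC(C)(O)CC(=O)O[C@H](CC=C(C)C)C1=CC(=O)c2c(O)ccc(O)c2C1=O`) reads > 100000 nM, which is a limit of the assay and not a number. Going by these compounds, it is the only one of the three at that limit, as the limit of > 100000 nM in this assay, at which 1 of the 3 values shown sits, records, so its true position is unknown.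

Compound 4 (`CC(C)=CC[C@@H](OC(=O)CC(C)(O)C(C)C)C1=CC(=O)c2c(O)ccc(O)c2C1=O`) differs from compound 3 by isopropyl in place of hexyl on a saturated chain carbon bound to an oxygen on a saturated carbon and two saturated chain carbons: isopropyl in place of hexyl. Among the measured compounds shown here, only one measured step touches this part of the side chain, namely an at least 1.6-fold higher number from compound 1 to compound 3 (0.22 log units; that floor lies within the scatter), where 1-hydroxy-1-methylheptyl replaces 1-hydroxybutyl. That step is only a floor, and the floor lies within the scatter, so it gives weak guidance. The change to 1-hydroxy-1,2-dimethylpropyl runs back in the direction of compound 1, which gives 59300 nM, so a move towards a lower number is expected. The assay may again report only a limit. The expected step is an at least 1.4-fold lower number from compound 3 to compound 4 (0.15 log units; that floor lies within the scatter), a small one. Compound 4 is estimated at 70000 nM, with an expected range of 35000 nM to 100000 nM.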

Compound 4, half-maximal inhibitory concentration: 27700 nM
Compound 4: the middle estimate sits 2.5-fold (0.40 log units) above what was measured; the measured number lies below the stated range.
By their numbers in this assay, from the lowest: compound 4; then compounds 1 and 2 (each within the scatter of the next). At a limit, above all of these: compound 3.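

In this assay, among the compounds shown here, isopropyl in place of hexyl on a saturated chain carbon bound to an oxygen on a saturated carbon and two saturated chain carbons gives the first step at this position that clears the scatter, with an at least 3.6-fold lower number from compound 3 to compound 4 (0.55 log units; beyond the scatter) for this change. The 1-hydroxy-1,2-dimethylpropyl group of compound 4 also separates from the two compounds that could not be told apart, with a 2.1-fold lower number from compound 1 to compound 4 (0.33 log units; beyond the scatter) against the 1-hydroxybutyl group and a 2.3-fold lower number from compound 2 to compound 4 (0.35 log units; beyond the scatter) against the 2-methoxyethyl ether, which makes compound 4 the most potent of the four in this assay. Going by these compounds, compound 3 stands only at a limit of the assay, so the step from it is a floor and its full size stays unknown: the limit of > 100000 nM in this assay, at which 1 of the 4 values shown sits.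

The compounds shown leave open whether the gain belongs to the isopropyl group itself, since a cyclopropyl or tert-butyl group at the same place would be needed to separate it from a simple shortening of the chain. They also leave open what an amine or a carboxylic acid on this side chain would do, and whether the tertiary hydroxyl group of compound 4 is needed at all.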